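A few compounds are considered here, and "the series" means these few. Any claim that something is new, unique, unknown or untested is made for them only; others in the source may bear on it.

Series notes. The shared core is that of compound 1 `CCc1ccc(NC2=CC(=O)c3c(nc4n3[C@H]3OC[C@@H](O)[C@H]3OC4)C2=O)cc1`, which carries a (4-ethylphenyl)amino group on the double-bonded ring carbon. In a functional assay on MCF7 cells (Homo sapiens) for inhibition, read by sulforhodamine B assay (a higher number here means a weaker inhibitor, a lower number a stronger inhibitor), compound 1 gives 8990 nM, the only numerical result so far in this set. Compound 2 `O=C1C=C(NC2CCCC2)C(=O)c2c1nc1n2[C@H]2OC[C@@H](O)[C@H]2OC1` bears a cyclopentylamino group in the same place. In this assay compound 2 gives > 16000 nM, which is a limit of the assay and not a number. Thus (the limit of > 16000 nM in this assay, at which 1 of the 2 values shown sits).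

Compound 3 `O=C1C(NC2CC2)=CC(=O)c2c1nc1n2[C@H]2OC[C@@H](O)[C@H]2OC1` is not yet measured. Against compound 1 the difference is cyclopropyl in place of 4-ethylphenyl on an amine nitrogen. Going by the values given here, no step between two measured compounds in this assay exists to calibrate this change, so the size of the step can only be expected, not derived. Compound 2, with a small saturated ring on that nitrogen, sits at > 16000 nM in this assay, and compound 3 also carries a small saturated ring there. The expectation is therefore a step from compound 1 toward weaker inhibition, beyond the scatter, with a fair chance that only a limit is returned. For compound 3 the estimated value in this assay is 20000 nM, within a range of 8000 nM to 50000 nM, which means an expected step of a 2.2-fold higher number from compound 1 to compound 3 (0.35 log units; beyond the scatter).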

Compound 3, half-maximal inhibitory concentration: > 16000 nM
Compound 3: a limit, no number; the forecaster's own chance of this, stated with the estimate: 60%; the middle value is on the limit's open side.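

In this assay, going by these compounds alone, the change of cyclopropyl in place of 4-ethylphenyl on an amine nitrogen gives the first step that can be read at this position: an at least 1.7-fold higher number from compound 1 to compound 3 (0.25 log units; that floor lies within the scatter). This step is only a floor, and that floor alone does not establish a loss of inhibition beyond the scatter, although the true size of the change may be larger. What the result adds is that a value for this change is now bounded on one side only, and the set now rests mostly on limits of the assay rather than on numbers: the limit of > 16000 nM in this assay, at which 2 of the 3 values shown sit.

Still open, going by these compounds, is whether the value of compound 1 depends on the aromatic ring itself or on its ethyl group, a question that an unsubstituted phenyl, a benzyl group or a longer straight alkyl chain on the same amine nitrogen would help to separate. With only compound 1 giving a number, no trend across groups at this position can yet be stated, and a carboxylic acid or a methoxy group on the phenyl ring remains equally unplaced.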